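A Chloro Added to the Phenoxy Ring of Compound 3

A few compounds are considered here, and "the series" means these few. Any claim that something is new, unique, unknown or untested is made for them only; others in the source may bear on it.

Of the compounds shown here, three have been measured in an assay on isolated protein for binding affinity to 5-hydroxytryptamine receptor 7 (Homo sapiens); on this read-out lower numbers stand for stronger inhibition and higher numbers for weaker inhibition. Compound 1 `O=C1CC(CN2CCC(Oc3ccccc3)CC2)CCc2ccccc21` gives 18.6 nM, compound 2 `Cc1ccccc1OC1CCN(CCC2CCCc3ccccc3C2=O)CC1` gives 11.2 nM, and compound 3 `O=C1c2ccccc2CCCN1CCN1CCC(Oc2ccccc2)CC1` gives 20.4 nM. Compound 3 has the highest of the three numbers, yet its gap to compound 1 and its gap to compound 2 both lie within the usual scatter of repeated measurements, so the three stand together. Compound 4 `O=C1c2ccccc2CCCN1CCN1CCC(Oc2ccc(Cl)cc2)CC1` differs from compound 3 in one place: chloro in place of hydrogen on an aromatic carbon. Among the compounds with values here, no step between two measured compounds matches this change, so nothing measured tells how large its effect is. A modest step, probably toward a lower number, is expected in this assay. The number estimated for compound 4 is 14 nM, with a range from 5 nM to 40 nM, which means an expected step of a 1.5-fold lower number from compound 3 to compound 4 (0.16 log units; within the scatter).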

Compound 4, inhibition constant: 11.8 nM
The estimate for compound 4 lay 1.2-fold (0.07 log units) above the measured number; low and high end bracket the measured number.
By their numbers in this assay, from the lowest: compounds 2, 4, 1 and 3 (each within the scatter of the next).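

In this assay, replacing phenoxy with 4-chlorophenoxy gives a 1.7-fold lower number from compound 3 to compound 4 (0.24 log units; within the scatter), so this position, para to a large group, accepts a chloro without a change that stands clear of the usual scatter. Within the data shown here, this is the first measured pair that isolates a change on this ring, and it gives the step a measured size. No measured evidence here explains the result. Still open, from the compounds shown here alone, is whether a fluoro, a methoxy or an amine at this position would give a step beyond the scatter, and whether chloro elsewhere on the ring would behave alike.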